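Methylsulfonyl for Methylsulfanyl on Two Related Cores

The source may hold more compounds than are shown below. What is called first, only, known or untested is meant among the compounds shown, and "the series" means these compounds.

Compound 1 `CSc1ccc(Nc2ncnc3sc(Nc4c(Cl)cccc4Cl)nc23)cc1` and compound 2 `CS(=O)(=O)c1ccc(Nc2ncnc3sc(Nc4c(Cl)cccc4Cl)nc23)cc1` share one core and differ by methylsulfonyl in place of methylsulfanyl on an aromatic carbon. In a functional assay on HEK293 cells for antagonist activity at transient receptor potential cation channel subfamily V member 1 (Homo sapiens), read by calcium flux (a lower number here means a stronger inhibitor, a higher number a weaker inhibitor), compound 1 gives 96 nM, while compound 2 gives 5 nM, so that the step is a 19-fold lower number from compound 1 to compound 2 (1.28 log units; beyond the scatter). Compound 3 `CSc1nc(Nc2ccc(C(F)(F)F)c(Cl)c2)c2nc(Nc3c(Cl)cccc3Cl)sc2n1` carries the same methylsulfanyl group on a different core; the difference between the two cores is not broken down here. In this assay compound 3 gives 224 nM, the highest of the three numbers. Compound 4 `CS(=O)(=O)c1nc(Nc2ccc(C(F)(F)F)c(Cl)c2)c2nc(Nc3c(Cl)cccc3Cl)sc2n1` differs from compound 3 by methylsulfonyl in place of methylsulfanyl on an aromatic carbon. This is the same kind of change as before, yet its place is now on a six-membered aromatic ring with 2 nitrogen, between two ring nitrogen atoms, rather than on a ring of carbon only, para to a large group. A step of an 11-fold lower number from compound 3 to compound 4 (1.05 log units; beyond the scatter) is expected, somewhat smaller than the earlier one, because the same change on the first core gave a 19-fold lower number from compound 1 to compound 2 (1.28 log units; beyond the scatter) and the surroundings here are not the same. Compound 4 is thus estimated at 20 nM, within 6 nM to 70 nM.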

Compound 4, half-maximal inhibitory concentration: 274 nM
Estimate against measurement, compound 4: 14-fold (1.14 log units) below; the whole stated range lies below it.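

In this assay the change gives a 1.2-fold higher number from compound 3 to compound 4 (0.09 log units; within the scatter), so methylsulfonyl in place of methylsulfanyl leaves no readable difference on the second core. The large step on the first core therefore did not carry over to the second: the same change on two cores in this assay, a 19-fold lower number (1.28 log units; beyond the scatter) from compound 1 to compound 2 and a 1.2-fold higher number (0.09 log units; within the scatter) from compound 3 to compound 4, 23-fold (1.37 log units) apart, beyond the scatter of two such steps This shows that a step seen on the core of compound 1 cannot be assumed on the core of compound 3, but with only these two pairs it does not show which difference between the two cores separates the steps.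

The compounds shown leave open how the step would read with the change on a ring of carbon only on the core of compound 3. They also leave open how an amine or a carboxylic acid would read in the place between two ring nitrogen atoms.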